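Swapping dimethylamino on a shorter-lived compound

The compounds below may be only part of what the source reports. "The series", "measured", "known", "first", "only" and "open" are said of these compounds alone.

In an ADME assay on microsomes from liver (Rattus norvegicus, strain Sprague-Dawley) for metabolic stability, read by HPLC, using NADPH, with stated times of 5 min and 60 min, tested at 10 uM (on this read-out lower numbers stand for a shorter-lived compound and higher numbers for a longer-lived compound), compound 1 (`CC(C)(C)c1ccc(C(=O)NCc2c(F)cc(NS(C)(=O)=O)cc2F)cc1`) gives 2.42 h and compound 2 (`CN(C)c1ccc(C(=O)NCc2ccc(NS(C)(=O)=O)cc2Cl)cc1`) gives 0.883 h as the lower of the two numbers, a gap beyond the usual scatter. Compound 3 (`CC(C)(O)c1ccc(C(=O)NCc2ccc(NS(C)(=O)=O)cc2Cl)cc1`) has 1-hydroxy-1-methylethyl in place of dimethylamino on an aromatic carbon of compound 2 (1-hydroxy-1-methylethyl in place of dimethylamino on an aromatic carbon) and keeps the rest. Going by the values given here, no measured pair shows this change alone. Compound 1 has no dimethylamino group and stands at 2.42 h despite other differences, so a modest rise just beyond the scatter is expected in this assay for compound 3. The estimated step is a 2.3-fold higher number from compound 2 to compound 3 (0.36 log units; beyond the scatter) in size. Compound 3 is expected at 2 h with an estimated range of 0.9 h to 4.5 h for repeated measurements.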

Compound 3, half-life: 20.2 h
Compound 3: middle estimate off by 10-fold (1.00 log units), on the low side; the whole stated range lies below it.
By their numbers in this assay, from the lowest: compound 2; then compound 1; then compound 3.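

With the rest of the molecule unchanged, putting 1-hydroxy-1-methylethyl in place of dimethylamino on this aromatic carbon, para to a large group, gives a 23-fold higher number from compound 2 to compound 3 (1.36 log units; beyond the scatter) in this assay. This single position can therefore move the half-life by a large amount. Nothing available here explains why the step is so large.

As far as these compounds go, it remains open whether another group at this position, such as a carboxylic acid or a methoxy group, would give a similar step. The same swap on the core of compound 1 is also untested among the compounds shown.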